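The source may hold more compounds than are shown below. What is called first, only, known or untested is meant among the compounds shown, and "the series" means these compounds.

Of the compounds shown here, three that share one core have been measured in an assay on HEK293 cells for displacement of a labelled ligand from 5-hydroxytryptamine receptor 7 (Homo sapiens), read by scintillation counting, with a stated time of 30 min; on this read-out lower numbers stand for stronger inhibition and higher numbers for weaker inhibition. Compound 1 `CN(CCCN1CCN(c2ccccc2)CC1)c1cccc(F)c1` gives 112 nM, compound 2 `CN(CCCN1CCN(c2ccccc2)CC1)c1cccc(O)c1` gives 20 nM, and compound 3 `NC(=O)c1cccc(NCCCN2CCN(c3ccccc3)CC2)c1` gives 63.3 nM. Among these three numbers compound 3 stands second highest: its value and that of compound 1 lie within the usual scatter of each other, while compound 2 sits clearly lower than both. For the measured compounds named here, the only step between two measured compounds that differ in a single place is a 5.6-fold lower number from compound 1 to compound 2 (0.75 log units; beyond the scatter), a hydroxy taking the place of a fluoro on an aromatic carbon.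

Compound 4 `OCc1cccc(NCCCN2CCN(c3ccccc3)CC2)c1` has not yet been measured. It differs from compound 3 in one place: hydroxymethyl in place of carbamoyl on an aromatic carbon. Going by the values given here, no measured step concerns this particular exchange. The step from compound 1 to compound 2 swaps a different pair of groups, so it only shows that replacing one small group on this ring with another can shift the number by a modest amount in this assay. With both the leaving and the entering group being small, the expected step is a 1.3-fold lower number from compound 3 to compound 4 (0.10 log units; within the scatter), which would not go beyond the scatter. Compound 4 is therefore estimated to give about 50 nM in this assay, with a likely range from 20 nM to 150 nM.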

Compound 4, inhibition constant: 109 nM
Compound 4: middle estimate off by 2.2-fold (0.34 log units), on the low side, and the stated range covers the measured number.
By their numbers in this assay, from the lowest: compound 2; then compounds 3, 4 and 1 (each within the scatter of the next).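

At this position, on an aromatic carbon meta to a large group, hydroxymethyl in place of carbamoyl gives a 1.7-fold higher number from compound 3 to compound 4 (0.24 log units; within the scatter), so this assay does not tell these two groups apart. For the compounds shown here, the exchange takes away the nitrogen and the double bond outside the aromatic ring and lowers the heavy-atom count from 3 to 2, while each group still counts 1 hydrogen-bond donor and 1 hydrogen-bond acceptor; this is the first measured sign that, on this core, such a swap can leave the number inside the usual scatter. Nothing is available here that would explain this result.

The compounds shown leave open whether a different group at this position, such as an amine, a carboxylic acid or a longer chain carrying the hydroxy at its end, would move the number beyond the scatter. They also leave open whether the clear step seen between fluoro and hydroxy, a 5.6-fold lower number from compound 1 to compound 2 (0.75 log units; beyond the scatter), would appear in the same way on the core of compound 3, which has no step of that kind among these compounds.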